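Methoxy added to an inactive thiazolylaminoenone

The source may report more compounds than this note shows. Statements on the series, on what has been measured and on what is new or still open speak of the compounds shown alone.

Measured compounds:
- Compound 1 `CS/C(=C/C(=O)c1ccc(C)cc1)Nc1nc2ccccc2s1`: 21100 nM
- Compound 2 `CCOc1ccc2nc(N/C(=C\C(=O)c3ccccc3)SC)sc2c1`: "not active" (no number reported)
- Compound 3 `CS/C(=C/C(=O)c1ccc(Cl)cc1)Nc1nc2ccccc2s1`: "not active" (no number reported)

All three share the same core, and all were tested in an assay on isolated protein for inhibition of lysosomal alpha-glucosidase (Homo sapiens); a higher number here means a weaker inhibitor, a lower number a stronger inhibitor. Among the compounds with values here, compound 1 is the only one that gives a number, and that number is a weak one: 21100 nM. Compound 2 stands with no number at all; in this assay compound 2 is recorded as "not active" (no number reported). Compound 3 is likewise recorded as "not active" (no number reported), so two of the three compounds show no measurable inhibition, and the third is weak.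

Compound 4 `CCOc1ccc2nc(N/C(=C\C(=O)c3ccc(OC)cc3)SC)sc2c1` is the next compound. It differs from compound 2 in one place: methoxy in place of hydrogen on an aromatic carbon. Within the data shown here, no step between two measured compounds mirrors this change, so there is no measured guide to its size or direction. Given that compound 2 shows no activity and compound 1, the only active one, is weak, compound 4 is expected to remain weak or inactive, and any change is expected to stay within the scatter rather than beyond it. The estimate for compound 4 in this assay is 50000 nM, within a range of 15000 nM to 200000 nM.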

Compound 4, half-maximal inhibitory concentration: "not active" (no number reported)
Nothing numeric was reported for compound 4, so the estimate cannot be set against anything.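

Compound 2 and compound 4 are both recorded as "not active" in this assay and neither has a number, so no step can be read from phenyl to 4-methoxyphenyl. The compounds shown leave open whether this methoxy changes inhibition at all. No measured evidence bears on this result.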